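Dropping the Iodo Group: Compound 3 to Compound 4

This account rests on a few compounds, and the source may have more. Where it says the series, first, only, none or still open, it means among the compounds named here.

Measured compounds:
compound 1 `CC(=NNC(=S)Nc1cccc(I)c1)c1ccccn1` — 61 nM
compound 2 `C/C(=N/NC(=S)Nc1ccccc1F)c1ccccn1` — 3.1 nM
compound 3 `C/C(=N/NC(=S)Nc1cccc(I)c1)c1ccccn1` — 61 nM

In a functional assay on T98G cells (Homo sapiens) for cytotoxicity, read by MTT assay, with a stated time of 48 h (on this read-out higher numbers stand for weaker inhibition and lower numbers for stronger inhibition), compound 3 gives 61 nM, level with compound 1 and together with it the highest of the three numbers; compound 2 gives 3.1 nM, a far lower number that lies beyond the scatter. Among the measured compounds shown here, the only measured step is no change at the digits printed from compound 1 to compound 3 (within the scatter), and it concerns no change of atoms at all: the fact that one of compounds 1 and 3 is drawn with a defined configuration and the other without, at the place where they differ. For the measured compounds named here, no measured step therefore speaks to the removal of a group from the ring.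

Compound 4 `C/C(=N/NC(=S)Nc1ccccc1)c1ccccn1` differs from compound 3 by hydrogen in place of iodo on an aromatic carbon. Going by the values given here, compound 2 shows that a different halogen at a different place goes with a much lower number, but no measured compound lacks the halogen altogether, so the direction of this step is open. The step is expected to be modest, a 1.4-fold lower number from compound 3 to compound 4 (0.13 log units; within the scatter), with wide uncertainty. Compound 4 is estimated to give 45 nM, within a range of 10 nM to 200 nM.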

Compound 4, half-maximal inhibitory concentration: 6.81 nM
Estimate against measurement, compound 4: 6.6-fold (0.82 log units) above; measured number below the stated range.
By their numbers in this assay, from the lowest: compound 2; then compound 4; then compounds 1 and 3 (each within the scatter of the next).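

Replacing iodo with hydrogen gives a 9.0-fold lower number from compound 3 to compound 4 (0.95 log units; beyond the scatter) in this assay, the first measured sign that what sits on this aromatic carbon can move the number well beyond the scatter. Removing fluoro from compound 2 gives a 2.2-fold higher number from compound 2 to compound 4 (0.34 log units; beyond the scatter), a smaller step in the opposite direction, so compound 4 now serves as a halogen-free reference: iodo goes with a higher number than hydrogen, and fluoro with a lower one. Nothing measured here explains either step.

The compounds shown leave open whether these opposite steps follow the identity of the halogen or its place on the ring, with no two of them carrying different halogens at the same place. They also do not tell how an amine or a methoxy group on this aromatic carbon would compare with hydrogen.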